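Aryl exchange on the piperazine oxalamide series

The source may report more compounds than this note shows. Statements on the series, on what has been measured and on what is new or still open speak of the compounds shown alone.

Measured compounds:
compound 1 `O=C(c1cc(-c2cn[nH]c2)on1)N1CCC(Cc2ccc(Cl)cc2)CC1`: 29.2 mL/min/kg
compound 2 `COc1ccc(N2CCN(C(=O)C(=O)Nc3ccc4[nH]c(=O)oc4c3)CC2)cc1`: "not determined" (no result reported)

In an ADME assay on the whole organism (Rattus norvegicus, strain Sprague-Dawley) for pharmacokinetics, using cassette dosing, at a dose of 0.5 mg/kg by the intravenous route (a lower number here means slower removal, a higher number faster removal of the compound), compound 1 gives 29.2 mL/min/kg. Among the compounds with values here, compound 2 returned no number in this assay, so it stands nowhere on the scale and no step from it can be sized or given a direction. Compound 3 `O=C(Nc1ccc2[nH]c(=O)oc2c1)C(=O)N1CCN(c2ccc(Cl)c(F)c2)CC1` differs from compound 2 as follows: 4-chloro-3-fluorophenyl in place of 4-methoxyphenyl on an amine nitrogen in a ring. With no value for compound 2, the only anchor for this assay is compound 1, a different scaffold. Compound 3 is therefore expected to sit near that anchor, at an estimated 30 mL/min/kg with a range of 12 mL/min/kg to 70 mL/min/kg.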

Compound 3, clearance: 5.6 mL/min/kg
Compound 3: the middle estimate sits 5.4-fold (0.73 log units) above what was measured, and the stated range ends above it.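

Within the data shown here, compound 2 has no number in this assay so no step from it to compound 3 can be read. Going by these compounds, what exchanging 4-methoxyphenyl for 4-chloro-3-fluorophenyl does to clearance stays open. No measured evidence bears on this result.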